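Iodo for amino on the shared core of compound 1

The source may hold more compounds than are shown below. What is called first, only, known or untested is meant among the compounds shown, and "the series" means these compounds.

In an ADME assay on cells (Fibroblast, Homo sapiens) for inhibition, read by MTT assay, with a stated time of 24 h (on this read-out higher numbers stand for weaker inhibition and lower numbers for stronger inhibition), compound 1 `Nc1ccc(C(=O)N/N=C/c2ccc3c(c2)no[n+]3[O-])cc1` gives > 200000 nM, which is a limit of the assay and not a number. Compound 2 `CCCc1ccc(C(=O)N/N=C/c2ccc3c(c2)no[n+]3[O-])cc1` gives > 200000 nM, likewise a limit. Compound 3 `O=C(N/N=C/c1ccc2c(c1)no[n+]2[O-])c1ccc(Br)cc1` gives > 200000 nM, again only a limit. All three values sit at the limit of > 200000 nM in this assay, at which 3 of the 3 values shown sit, so the steps a step that the two limits leave unreadable from compound 1 to compound 2, a step that the two limits leave unreadable from compound 1 to compound 3 and a step that the two limits leave unreadable from compound 2 to compound 3 carry no readable size or direction. Compound 4 `O=C(N/N=C/c1ccc2c(c1)no[n+]2[O-])c1ccc(I)cc1` differs from compound 1 by iodo in place of amino on an aromatic carbon. Going by the values given here, the related bromo and propyl exchanges give no measured step to build on, so the outcome for compound 4 in this assay can only be expected to stay at the same limit, with an estimated step that the limit leaves unreadable from compound 1 to compound 4. Compound 4 is therefore estimated at 300000 nM, within a range of 150000 nM to 1000000 nM.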

Compound 4, half-maximal inhibitory concentration: > 200000 nM
Compound 4 gave a limit, no number (the forecaster's own chance of this, stated with the estimate: 85%); the middle value does not contradict the limit.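

Compound 4 gives a limit and not a number, so its steps from compound 1, compound 2 and compound 3 cannot be read: the limit of > 200000 nM in this assay, at which 4 of the 4 values shown sit.

The compounds shown leave open which change on the shared core, if any, would bring a measurable value.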